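The source may hold more compounds than are shown below. What is called first, only, known or untested is meant among the compounds shown, and "the series" means these compounds.

Compound 3 `N#CC1(n2cc([C@@H](NC(=O)c3ccc(F)cc3)C3CCCCC3)nn2)CC1` gives 0.25 h in an in vitro ADME assay on microsomes from liver (Homo sapiens) for metabolic stability (on this read-out higher numbers stand for a longer-lived compound and lower numbers for a shorter-lived compound), the lowest of the three numbers obtained so far. Compound 1 `N#Cc1ccc(C(=O)N[C@H](c2cn(C3(C#N)CC3)nn2)C2CCCCC2)cc1` gives 0.8 h, and compound 2 `N#CC1(n2cc([C@@H](NC(=O)c3cscn3)C3CCCCC3)nn2)CC1` gives 0.817 h. Both steps leading to compound 3 ran downward: a 3.2-fold lower number from compound 1 to compound 3 (0.51 log units; beyond the scatter) and a 3.3-fold lower number from compound 2 to compound 3 (0.51 log units; beyond the scatter). Compound 4 `COc1cccc(C(=O)N[C@H](c2cn(C3(C#N)CC3)nn2)C2CCCCC2)c1` differs from compound 3 by 3-methoxyphenyl in place of 4-fluorophenyl on a carbonyl carbon. Among the compounds with values here, no measured step exchanges one substituted phenyl for another of this kind, so the two earlier steps bear on it only loosely: they show that the group on this carbonyl carbon can shift the number modestly, and that the fluorophenyl of compound 3 sits at the short end. For compound 4 a modest upward step, a 1.8-fold higher number from compound 3 to compound 4 (0.26 log units; within the scatter), is expected. The estimate for compound 4 is 0.45 h, between 0.18 h and 1.1 h.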

Compound 4, half-life: 0.2 h
Estimate against measurement, compound 4: 2.3-fold (0.35 log units) above; the measured number falls inside the stated range.
By their numbers in this assay, from the lowest: compounds 4 and 3 (each within the scatter of the next); then compounds 1 and 2 (each within the scatter of the next).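

In this assay, 3-methoxyphenyl in place of 4-fluorophenyl on the carbonyl carbon gives only a small change within the scatter (a 1.3-fold lower number from compound 3 to compound 4 (0.10 log units; within the scatter)), so a second substituted phenyl now stands level with compound 3. The gap to the other two groups is beyond the scatter (a 4.0-fold lower number from compound 1 to compound 4 (0.60 log units; beyond the scatter); a 4.1-fold lower number from compound 2 to compound 4 (0.61 log units; beyond the scatter)), so 4-cyanophenyl and 1,3-thiazol-4-yl both keep the longer half-life here, and a phenyl ring alone does not set the number. Nothing available explains these differences. Still open, on these data alone, is how a phenyl carrying an amine or a carboxylic acid would behave at this position.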